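The compounds below may be only part of what the source reports. "The series", "measured", "known", "first", "only" and "open" are said of these compounds alone.

Compound 1 `Cc1c(O)ccc2c1[C@H](Cn1cc(-c3ccc(C(F)(F)F)cc3)nn1)[C@@]13CC(=O)[C@@](C)(CC[C@@H]21)C3` and compound 2 `C=C1C(=O)[C@]23C[C@@]1(O)CC[C@H]2c1ccc(O)c(C)c1[C@@H]3Cn1cc(-c2ccc(OC)cc2)nn1` share a core but differ in several places at once; the difference between the two cores is not broken down here. In a functional assay on HL-60 cells (Homo sapiens) for cytotoxicity, read by MTT assay, with a stated time of 4 days (a higher number here means a weaker inhibitor, a lower number a stronger inhibitor), compound 2 gives 1150 nM. Compound 1 reaches only a limit in this assay, at > 20000 nM. Compound 3 `Cc1ccc(S(=O)(=O)Oc2ccc3c(c2C)[C@H](Cn2cc(-c4ccc(C(F)(F)F)cc4)nn2)[C@@]24CC(=O)[C@@](C)(CC[C@@H]32)C4)cc1` carries the change (4-methylphenyl)sulfonyl in place of hydrogen on an oxygen on an aromatic ring relative to compound 1. Compound 3 likewise stops at a limit in this assay, at > 20000 nM. The step that the two limits leave unreadable from compound 1 to compound 3 is therefore not readable, because of the limit of > 20000 nM in this assay, at which 2 of the 3 values shown sit.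

Compound 4 `C=C1C(=O)[C@]23C[C@@]1(O)CC[C@H]2c1ccc(OS(=O)(=O)c2ccc(C)cc2)c(C)c1[C@@H]3Cn1cc(-c2ccc(OC)cc2)nn1` stands to compound 2 as compound 3 stands to compound 1, with the same change (4-methylphenyl)sulfonyl in place of hydrogen on an oxygen on an aromatic ring at the same place. The measured pair gives no readable size for this change; the expectation for compound 4 rests on compound 2 at 1150 nM alone. Compound 4 is expected at 2500 nM, between 700 nM and 15000 nM, the step of a 2.2-fold higher number from compound 2 to compound 4 (0.34 log units; beyond the scatter) estimated as modest.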

Compound 4, half-maximal inhibitory concentration: 1020 nM
Compound 4: the middle estimate sits 2.5-fold (0.39 log units) above what was measured; measured number inside the range.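

In this assay, hydroxy replaced by ((4-methylphenyl)sulfonyl)oxy on the core of compound 2 gives a 1.1-fold lower number from compound 2 to compound 4 (0.05 log units; within the scatter), so compound 2 and compound 4 read alike. On the core of compound 1 the same change cannot be read: the limit of > 20000 nM in this assay, at which 2 of the 4 values shown sit. The series therefore holds one readable instance of this change, which does not show whether the result carries from one core to the other.

Open, on these data alone, is how a smaller or different group on that oxygen on an aromatic ring would read, such as acetyl, or a longer chain ending in an amine or a carboxylic acid. Also open, as far as these compounds go, is the readout of this change on a core that gives a measurable number with the trifluoromethyl-bearing ring.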